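The compounds below may be only part of what the source reports. "The series", "measured", "known", "first", "only" and "open" are said of these compounds alone.

Of the compounds shown here, three have so far been measured in an assay on isolated protein (Salivary gland) for displacement of a labelled ligand from Alpha-1A adrenergic receptor (Rattus norvegicus); on this read-out lower numbers stand for stronger inhibition and higher numbers for weaker inhibition. Compound 1 `COC(=O)[C@@H]1c2cc(/C=C/C(=O)NCCCCNC(=N)N)ccc2O[C@H]1c1ccc(O)cc1` gives 560000 nM in this assay, and compound 2 `N=C(N)NCCCCNC(=O)/C=C/c1ccc(O)cc1` gives 57600000 nM. Compound 3 `N=C(N)NCCCCNC(=O)[C@@H]1c2cc(/C=C/C(=O)O)ccc2O[C@H]1c1ccc(O)cc1` does not give a number in this assay but only a limit, > 100000000 nM. This is the limit at which one of the three values sits (the limit of > 100000000 nM in this assay, at which 1 of the 3 values shown sits), so compound 3 stands at the weak end of what this assay can report.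

Compound 4 `N=C(N)NCCCCNC(=O)[C@H]1c2cc(/C=C/C(=O)O)ccc2O[C@@H]1c1ccc(O)cc1` is the next compound. It differs from compound 3 in this way: the two compounds have the same atoms and bonds; at least one stereo element is drawn with a configuration in one of them and without one in the other: 2 of 4 stereo elements differ; a stereocentre at a saturated ring carbon is drawn R in compound 3 and S in compound 4; a stereocentre at a saturated ring carbon is drawn R in compound 3 and S in compound 4. Among the compounds with values here, no measured pair in this set differs only by such a change, so no step of this kind can be read from the data. With nothing to point to, the reviewer expects no shift beyond the usual scatter in this assay, in either direction. For compound 4 the estimate in this assay is 100000000 nM, with a range from 10000000 nM to 300000000 nM. The expected step is therefore a number no higher from compound 3 to compound 4 (the limit leaves the size open), and a limit rather than a number is considered the likely outcome.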

Compound 4, half-maximal inhibitory concentration: > 100000000 nM
Compound 4 ended at the assay's limit; the forecaster's own chance of this, stated with the estimate: 70%; the middle value lies on the limit itself.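

Compound 3 and compound 4 both stand at a limit of the assay rather than at a number, so no step between them can be read: the limit of > 100000000 nM in this assay, at which 2 of the 4 values shown sit.

The compounds shown leave open whether the configuration at the two saturated ring carbons changes the result in this assay.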